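A few compounds are considered here, and "the series" means these few. Any claim that something is new, unique, unknown or untested is made for them only; others in the source may bear on it.

The study compares four compounds in a functional assay on HL-60 cells (Homo sapiens) for inhibition, read by CCK-8 assay, with a stated time of 48 h; on this read-out lower numbers stand for stronger inhibition and higher numbers for weaker inhibition. Compound 1 `Cc1ccc(-c2ccsc2S(=O)(=O)NCCNC(=O)Nc2cc(C(F)(F)F)cc(C(F)(F)F)c2)c(Oc2ccc(O)c(O)c2)c1` gives 3700 nM in this assay. Compound 3 `O=S(=O)(c1sccc1-c1ccccc1Oc1ccc(O)c(O)c1)N1CCN(C(=S)Nc2ccc(Cl)cc2)CC1` gives 5500 nM in this assay; how the core of compound 1 and the core of compound 3 differ is not broken down here, and the two numbers lie within the scatter of each other, so no order between them is claimed. Compound 2 `COc1ccc(Oc2ccccc2-c2ccsc2S(=O)(=O)N2CCN(C(=S)Nc3ccc(Cl)cc3)CC2)cc1OC` differs from compound 3 by 3,4-dimethoxyphenyl in place of 3,4-dihydroxyphenyl on an oxygen on an aromatic ring. In this assay compound 2 gives > 50000 nM, which is a limit of the assay and not a number. The measured step is an at least 9.0-fold higher number from compound 3 to compound 2 (0.95 log units; beyond the scatter), and its size rests on (the limit of > 50000 nM in this assay, at which 1 of the 3 values shown sits), so only its lower bound is known.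

Compound 4 `COc1ccc(Oc2cc(C)ccc2-c2ccsc2S(=O)(=O)NCCNC(=O)Nc2cc(C(F)(F)F)cc(C(F)(F)F)c2)cc1OC` has not yet been measured in this assay. It differs from compound 1 by 3,4-dimethoxyphenyl in place of 3,4-dihydroxyphenyl on an oxygen on an aromatic ring, the same change, at the same place, as that between compound 3 and compound 2. Going by the values given here, since an at least 9.0-fold higher number from compound 3 to compound 2 (0.95 log units; beyond the scatter) is the only measured instance of this change and lies beyond the scatter, a step of similar size, a 9.5-fold higher number from compound 1 to compound 4 (0.98 log units; beyond the scatter), is expected from compound 1 to compound 4. Compound 4 is therefore expected to give about 35000 nM in this assay, with a plausible range from 12000 nM to 100000 nM, and there is a real chance that this assay reports only a limit for compound 4.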

Compound 4, half-maximal inhibitory concentration: 5300 nM
The estimate for compound 4 lay 6.6-fold (0.82 log units) above the measured number; the whole stated range lies above it.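

In this assay, going by these compounds alone, putting 3,4-dimethoxyphenyl in place of 3,4-dihydroxyphenyl gives a 1.4-fold higher number from compound 1 to compound 4 (0.16 log units; within the scatter), so on the core of compound 1 this change produces no step that stands out from the scatter, while on the core of compound 3 the same change produced a large one, and the two steps do not agree: the same change on two cores in this assay, an at least 9.0-fold higher number (0.95 log units; beyond the scatter) from compound 3 to compound 2 and a 1.4-fold higher number (0.16 log units; within the scatter) from compound 1 to compound 4, at least 6.3-fold (0.80 log units) apart, beyond the scatter of two such steps The earlier step is known only as a lower bound, as compound 2 sits at a limit of the assay and not at a number: the limit of > 50000 nM in this assay, at which 1 of the 4 values shown sits. This shows that the step seen on one core cannot simply be carried to the other, but it does not show which part of the cores decides the outcome, for the cores of compound 1 and compound 3 differ in more than one place and only two pairs are available.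

The compounds shown leave open how the step would run with a phenyl carrying a single hydroxyl group or with ethoxy groups in place of the methoxy groups. Also open, from the compounds shown here alone, is how the same change would behave on a core differing from that of compound 3 in one place only, which could tie the disagreement to a single part of the core.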